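The compounds below may be only part of what the source reports. "The series", "measured", "known", "first", "only" and "open" are said of these compounds alone.

Compound 1 `CC(=O)Nc1cc(C)n(Cc2cc(Cl)ccc2OCc2ccccc2)n1`: > 3.7
Compound 2 `Cc1cc(NC(=O)C2CCCC2)nn1Cc1cc(Cl)ccc1OCc1ccccc1`: 3.5
Compound 3 `Cc1cc(NC(=O)CC2CCCCC2)nn1Cc1cc(Cl)ccc1OCc1ccccc1`: 3.2

These three compounds share one core and differ only in the group on the carbonyl carbon of the amide. In a physicochemical assay for lipophilicity, at pH 7.4 (a higher number here means a more lipophilic compound, a lower number a more polar compound), compound 3 gives 3.2, the lowest of the two plain numbers. Compound 2 gives 3.5, and the step of a number 0.30 log units lower from compound 2 to compound 3 (within the scatter) is small. For compound 1 the value > 3.7 is a limit of the assay, not a number. Even so, the step of a number at least 0.50 log units lower from compound 1 to compound 3 (beyond the scatter) is clear: the larger ring-bearing group went with a lower value, and a number at least 0.20 log units lower from compound 1 to compound 2 (that floor lies within the scatter) points the same way.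

Compound 4 `COC(=O)Nc1cc(C)n(Cc2cc(Cl)ccc2OCc2ccccc2)n1` has not yet been measured. It differs from compound 3 as follows: methoxy in place of cyclohexylmethyl on a carbonyl carbon. The measured steps suggest that shrinking the group on this carbonyl carbon raises the value, so the reverse of a number at least 0.50 log units lower from compound 1 to compound 3 (beyond the scatter) is the closest guide, though methoxy is not methyl and the value for compound 1 is only a limit. Compound 4 is therefore expected to come out higher than compound 3, an estimated step of a number 0.40 log units higher from compound 3 to compound 4 (beyond the scatter). The estimate for compound 4 is 3.6, expected to fall between 3.1 and 4.1.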

Compound 4, distribution coefficient: > 3.7
Compound 4: a limit, no number (the forecaster's own chance of this, stated with the estimate: 30%); middle value at least 0.10 log units from the limit.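

In this assay compound 4 gives > 3.7, which is a limit of the assay and not a number. Until now the group on this carbonyl carbon had varied only among groups of carbon, whereas methoxy brings in an oxygen and a hydrogen-bond acceptor, and it also loses the ring, yet the swap still gives a number at least 0.50 log units higher from compound 3 to compound 4 (beyond the scatter), while the comparison with the cyclopentyl compound gives a number at least 0.20 log units higher from compound 2 to compound 4 (that floor lies within the scatter). So a small group on this carbonyl carbon, whether joined through carbon as in compound 1 or through oxygen as in compound 4, gives a limit rather than a readable number, and the step between those two compounds cannot be read: the limit of > 3.7 in this assay, at which 2 of the 4 values shown sit.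

The compounds shown leave open what would happen with an amine or a carboxylic acid on this carbonyl carbon, or with an ethoxy group or a longer chain joined through oxygen. Such groups could show whether the oxygen or the small size of methoxy goes with the limit, which compound 4 alone cannot separate.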